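Farnesylthio chloromethyl ketones: dropping the acetamido group

A few compounds are considered here, and "the series" means these few. Any claim that something is new, unique, unknown or untested is made for them only; others in the source may bear on it.

Within the data shown here, compound 2 `CC(=O)N[C@@H](CSC/C=C(\C)CC/C=C(\C)CCC=C(C)C)C(=O)CCl` gives the lower of the two numbers so far: in a functional assay on MOLT-3 cells (Homo sapiens) (on this read-out lower numbers stand for stronger inhibition and higher numbers for weaker inhibition), compound 2 gives 1400 nM, while compound 1 `CC(=O)N[C@@H](CSC/C=C(\C)CC/C=C(\C)CCC=C(C)C)C(=O)C=[N+]=[N-]` gives 32200 nM, a step of a 23-fold lower number from compound 1 to compound 2 (1.36 log units; beyond the scatter). Compound 3 `CC(C)=CCC/C(C)=C/CC/C(C)=C/CSCCC(=O)CCl` differs from compound 2 by hydrogen in place of acetamido on a saturated chain carbon bound to a carbonyl carbon and a saturated chain carbon. Among the measured compounds shown here, no measured step touches this place; the only step known concerns the carbonyl carbon. For the measured compounds named here, with no direct precedent, a moderate weakening is expected for compound 3, estimated at 3500 nM with a range of 800 nM to 15000 nM, corresponding to an expected step of a 2.5-fold higher number from compound 2 to compound 3 (0.40 log units; beyond the scatter).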

Compound 3, half-maximal inhibitory concentration: 35500 nM
For compound 3 the middle estimate is 10-fold (1.01 log units) below the measured one, and the stated range ends below it.
By their numbers in this assay, from the lowest: compound 2; then compounds 1 and 3 (each within the scatter of the next).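

In this assay, hydrogen in place of acetamido on a saturated chain carbon bound to a carbonyl carbon and a saturated chain carbon gives a large step, a 25-fold higher number from compound 2 to compound 3 (1.40 log units; beyond the scatter). Among these compounds, the earlier pair touched only the carbonyl carbon, so this is the first sign that the acetamido place also matters, with the chloromethyl ketone held constant. No available data bear on the reason for this loss.

Open, from the compounds shown here alone, is whether an amine or a longer amide at this place would keep the number of compound 2. Also open, going by these compounds, is whether the same change would give a comparable step on compound 1.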